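Amide substituent change on the shared core

The source may report more compounds than this note shows. Statements on the series, on what has been measured and on what is new or still open speak of the compounds shown alone.

Measured so far in a functional assay on HCT-116 cells (Homo sapiens) for antiproliferative activity, read by MTT assay, with a stated time of 72 h; a higher number here means a weaker inhibitor, a lower number a stronger inhibitor:
- compound 1 `Cc1noc(C)c1-c1nn(Cc2ccc(C(=O)NC3CC3)cc2)c(=O)c2ccccc12`: > 100000 nM, which is a limit of the assay and not a number.
- compound 2 `Cn1cc(-c2nn(Cc3ccc(C(=O)NC4CCCC4)cc3)c(=O)c3ccccc23)cn1`: 14300 nM.
- compound 3 `O=C(Nc1ccccc1Cl)c1ccc(Nc2nn(Cc3ccc(C(=O)NC4CCCCC4)cc3)c(=O)c3ccccc23)cc1`: > 100000 nM, again a limit of the assay rather than a number.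

Going by the values given here, compound 2 is thus the only compound with an actual number in this assay; the other two entries are the limit of > 100000 nM in this assay, at which 2 of the 3 values shown sit. Among the compounds with values here, no pair among the measured compounds differs in a single place, so no measured step is available to calibrate the change that follows.

Compound 4 `Cn1cc(-c2nn(Cc3ccc(C(=O)NC4CC(C)(C)N([O])C(C)(C)C4)cc3)c(=O)c3ccccc23)cn1` differs from compound 2 by a group of 11 heavy atoms (9 carbon, 1 nitrogen, 1 oxygen; one six-membered non-aromatic ring with 1 hetero atom) in place of a group of 5 heavy atoms (5 carbon; one five-membered non-aromatic ring of carbon only), on an amide-type nitrogen. Within the data shown here, with no comparable measured step, the expectation rests only on the position of compound 2 and on the size of the structural change. The expected step from compound 2 to compound 4 is a 2.1-fold higher number from compound 2 to compound 4 (0.32 log units; beyond the scatter), a moderate weakening, though a step within the scatter cannot be excluded. Compound 4 is therefore estimated at 30000 nM, with a range from 6000 nM to 150000 nM, and a real chance that this assay returns only a limit for it.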

Compound 4, half-maximal inhibitory concentration: 50500 nM
Beside the measured number, compound 4's estimate is 1.7-fold (0.23 log units) below it; the range from low to high includes it.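

Going by these compounds alone, replacing cyclopentyl with the six-membered non-aromatic ring with one hetero atom, on the amide-type nitrogen, gives the first measured step at this position in this assay: a 3.5-fold higher number from compound 2 to compound 4 (0.55 log units; beyond the scatter). The group that enters has 11 heavy atoms where the group that leaves has 5, yet the step is only modest, so this position accepts a much larger group and still gives a measurable effect. Compound 4 returns a number and so is not among the entries at the limit, which is a limit of the assay and not a number: the limit of > 100000 nM in this assay, at which 2 of the 4 values shown sit.

Going by these compounds, whether the step follows from the larger ring or from its nitrogen and oxygen stays open, as a single step cannot separate them. A cyclohexyl group, or a piperidine ring with a hydrogen on its nitrogen, on the same amide of compound 2 would tell these apart.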